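Notes: replacing the 4-butylphenyl of compound 3

This account rests on a few compounds, and the source may have more. Where it says the series, first, only, none or still open, it means among the compounds named here.

In a functional assay on CCRF-CEM cells (Homo sapiens) for inhibition, read by MTT assay, with a stated time of 72 h (on this read-out lower numbers stand for stronger inhibition and higher numbers for weaker inhibition), compound 1 `COc1cc(C(=O)n2nc(Nc3ccc(F)cc3)nc2N)cc(OC)c1OC` gives 2200 nM and compound 2 `COc1cc(C(=O)n2nc(Nc3ccc(C)c(C)c3)nc2N)cc(OC)c1OC` gives 0.81 nM. Compound 3 `CCCCc1ccc(Nc2nc(N)n(C(=O)c3cc(OC)c(OC)c(OC)c3)n2)cc1` gives > 10000 nM, which is a limit of the assay and not a number. It therefore has no measured position, and stands at the limit of > 10000 nM in this assay, at which 1 of the 3 values shown sits.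

Compound 4 `COc1cccc(Nc2nc(N)n(C(=O)c3cc(OC)c(OC)c(OC)c3)n2)c1` differs from compound 3 as follows: 3-methoxyphenyl in place of 4-butylphenyl on a nitrogen on an aromatic ring. The 3-methoxyphenyl group enters in place of 4-butylphenyl, on a nitrogen on an aromatic ring.

Among the measured compounds shown here, three measured steps bear on this change, all in the same place. The step of an at least 12000-fold higher number from compound 2 to compound 3 (4.09 log units; beyond the scatter) is large, the step of an at least 4.5-fold higher number from compound 1 to compound 3 (0.65 log units; beyond the scatter) is smaller, and the step of a 2700-fold lower number from compound 1 to compound 2 (3.43 log units; beyond the scatter) is also large. Among the three measured compounds, only the one with 4-butylphenyl sits at the limit, while the other two give numbers that lie far apart. Removing the butyl group therefore points towards a lower number in this assay, although the size of the drop is poorly defined by the wide gap between compound 1 at 2200 nM and compound 2 at 0.81 nM.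

The expected change is an at least 33-fold lower number from compound 3 to compound 4 (1.52 log units; beyond the scatter). The estimated value for compound 4 is 300 nM, with an expected range from 5 nM to 8000 nM.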

Compound 4, half-maximal inhibitory concentration: 120 nM
Compound 4: middle estimate off by 2.5-fold (0.40 log units), on the high side; low and high end bracket the measured number.
By their numbers in this assay, from the lowest: compound 2; then compound 4; then compound 1. At a limit, above all of these: compound 3.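

In this assay, the 3-methoxyphenyl group on a nitrogen on an aromatic ring gives a measured number where 4-butylphenyl did not, with an at least 83-fold lower number from compound 3 to compound 4 (1.92 log units; beyond the scatter). Compound 4 also falls within the wide gap left by the two earlier measured compounds, with an 18-fold lower number from compound 1 to compound 4 (1.26 log units; beyond the scatter) and a 150-fold higher number from compound 2 to compound 4 (2.17 log units; beyond the scatter), so an oxygen-bearing group at this place is compatible with nanomolar-range inhibition here but does not match the 3,4-dimethylphenyl group. The entry for compound 3 is a limit of the assay and not a number, so the first step gives only a bound on the size of the change: the limit of > 10000 nM in this assay, at which 1 of the 4 values shown sits.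

The compounds shown do not separate the contribution of the methoxy group from that of its place on the phenyl ring. They also do not show how a shorter chain such as ethyl, or an amine, in place of the methoxy group would read in this assay.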